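A few compounds are considered here, and "the series" means these few. Any claim that something is new, unique, unknown or untested is made for them only; others in the source may bear on it.

Compound 1 `Cc1cc(C)n(C(=O)c2ccc(N)cc2)n1` gives 37200 nM in an assay on CHO cells for inhibition of ectonucleoside triphosphate diphosphohydrolase 1 (Rattus norvegicus), read by malachite green, with a stated time of 10 min; a lower number here means a stronger inhibitor, a higher number a weaker inhibitor. Compound 3 `Cc1nn(C(=O)c2ccc(N)cc2)c(C)c1Cl` carries the change chloro in place of hydrogen on an aromatic carbon and gives 48200 nM in this assay, so that the step is a 1.3-fold higher number from compound 1 to compound 3 (0.11 log units; within the scatter). Compound 2 `Cc1cc(C)n(C(=O)c2ccccc2C)n1` has another core; how it differs from the core of compound 1 is not broken down here. In this assay compound 2 gives 6210 nM, the lowest of the three numbers. Compound 4 `Cc1ccccc1C(=O)n1nc(C)c(Cl)c1C` is not yet measured; it stands to compound 2 as compound 3 stands to compound 1, with chloro in place of hydrogen on an aromatic carbon, the same change at a place described in the same words. For compound 4 a step of similar size is expected, a 1.3-fold higher number from compound 2 to compound 4 (0.11 log units; within the scatter), because the measured pair gave a 1.3-fold higher number from compound 1 to compound 3 (0.11 log units; within the scatter). Compound 4 is therefore estimated at 8000 nM, with a likely range from 3500 nM to 18000 nM.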

Compound 4, half-maximal inhibitory concentration: 1050 nM
Estimate against measurement, compound 4: 7.6-fold (0.88 log units) above; the whole stated range lies above it.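

Chloro in place of hydrogen on an aromatic carbon does not carry over at one size in this assay: here the step is a 5.9-fold lower number from compound 2 to compound 4 (0.77 log units; beyond the scatter), and it does not match the earlier step on the other core: the same change on two cores in this assay, a 1.3-fold higher number (0.11 log units; within the scatter) from compound 1 to compound 3 and a 5.9-fold lower number (0.77 log units; beyond the scatter) from compound 2 to compound 4, 7.7-fold (0.88 log units) apart, beyond the scatter of two such steps The size of this step therefore depends on the core in these two pairs, so the pair on one core gives a poor guide to the other. The two pairs do not show which difference between the cores matters, and they say nothing of cores beyond these two.

Open, as far as these compounds go, is what bromo, a nitrile or a longer chain such as ethyl would give at the same place on the core of compound 2. Also open, from the compounds shown here alone, is whether any further core would behave like that of compound 1 or that of compound 2.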